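Changing the Acid of Compound 3 to a Morpholine Group

The compounds below may be only part of what the source reports. "The series", "measured", "known", "first", "only" and "open" are said of these compounds alone.

Compound 1 `C=CC(=O)N(CC(=O)OCC)c1nc(-c2ccccc2)cs1` gives 19000 nM
Compound 2 `C=CC(=O)N(CC(=O)OC(C)(C)C)c1nc(-c2ccccc2)cs1` gives > 30000 nM (a limit)
Compound 3 `C=CC(=O)N(CC(=O)O)c1nc(-c2ccccc2)cs1` gives > 30000 nM (a limit)

In a functional assay on HT-29 cells (Homo sapiens) for antiproliferative activity, read by MTT assay, with a stated time of 72 h (a higher number here means a weaker inhibitor, a lower number a stronger inhibitor), compound 3 has no exact number, only a limit (> 30000 nM). Only compound 1 has a true measured value. Compound 4 `C=CC(=O)N(CC(=O)N1CCOCC1)c1nc(-c2ccccc2)cs1` has not been measured. It carries morpholin-4-yl in place of hydroxy on a carbonyl carbon.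

Going by the values given here, three measured steps bear on this change. They are an at least 1.5-fold higher number from compound 1 to compound 2 (0.19 log units; that floor lies within the scatter), an at least 1.5-fold higher number from compound 1 to compound 3 (0.19 log units; that floor lies within the scatter) and a step that the two limits leave unreadable from compound 2 to compound 3. The first two have floors within the scatter and the third cannot be sized, and none of them brings in morpholin-4-yl. No step beyond the scatter is therefore expected in this assay, in either direction.

The expected change is a number no higher from compound 3 to compound 4 (the limit leaves the size open).

For compound 4 the estimated value is 30000 nM, with an expected range from 14000 nM to 60000 nM.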

Compound 4, half-maximal inhibitory concentration: 13300 nM
For compound 4 the middle estimate is 2.3-fold (0.35 log units) above the measured one, outside the stated range (below it).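

In this assay, the carbonyl carbon whose other neighbour is a saturated chain carbon now shows a readable gain: morpholin-4-yl in place of hydroxy gives an at least 2.2-fold lower number from compound 3 to compound 4 (0.35 log units; beyond the scatter), and in place of tert-butoxy it gives an at least 2.2-fold lower number from compound 2 to compound 4 (0.35 log units; beyond the scatter). As far as these compounds go, both steps start from a limit of the assay, not from a number, so their true size stays unknown: the limit of > 30000 nM in this assay, at which 2 of the 4 values shown sit. Ethoxy is a different case, since morpholin-4-yl in its place gives a 1.4-fold lower number from compound 1 to compound 4 (0.15 log units; within the scatter), so these two groups cannot be told apart here.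

From the compounds shown here alone, what remains open is whether the ring oxygen of morpholin-4-yl matters or whether another amine on this carbonyl carbon would serve equally well. Piperidin-1-yl, which has no ring oxygen, or the open-chain dimethylamino would address this.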